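Adding a second chloro to the core of compound 3

The source may report more compounds than this note shows. Statements on the series, on what has been measured and on what is new or still open speak of the compounds shown alone.

Compound 1 `ClCc1cccc(Cn2cnc3ncnc(Cl)c32)c1`: 3380 nM
Compound 2 `ClCc1ccc(Cn2cnc3nc(Cl)nc(Cl)c32)cc1`: 3090 nM
Compound 3 `ClCc1ccccc1Cn1cnc2ncnc(Cl)c21`: 6910 nM

Of the compounds shown here, three have been tested in a functional assay on MDA-MB-231 cells (Homo sapiens) for cytotoxicity, read by sulforhodamine B assay, with a stated time of 48 h; on this read-out higher numbers stand for weaker inhibition of growth and lower numbers for stronger inhibition of growth. Compound 3 stands at the highest number of the three, beyond the scatter from both compound 1 and compound 2, so it is the weakest growth inhibitor of this set. Compound 1 and compound 2 lie within the scatter of each other, so nothing separates them. Compound 4 `ClCc1ccccc1Cn1cnc2nc(Cl)nc(Cl)c21` is the next compound to be measured. It differs from compound 3 in one place: chloro in place of hydrogen on an aromatic carbon, the new chloro sitting between two ring nitrogens of the core, meta to the chloro already present. Among the compounds with values here, no measured pair in this set isolates this change, since compound 1 and compound 2 also differ in where the chloromethyl arm sits. For this assay the step from compound 3 to compound 4 is therefore expected to be modest, at most a slight move toward stronger inhibition, given as a 1.4-fold lower number from compound 3 to compound 4 (0.14 log units; within the scatter). Compound 4 is expected to give 5000 nM, within a range from 2000 nM to 12000 nM.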

Compound 4, concentration for total growth inhibition: 910 nM
Compound 4: middle estimate off by 5.5-fold (0.74 log units), on the high side; measured number outside the range, below it.
By their numbers in this assay, from the lowest: compound 4; then compounds 2 and 1 (each within the scatter of the next); then compound 3.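

Swapping hydrogen for chloro on an aromatic carbon of the core, between two ring nitrogen atoms, gives a 7.6-fold lower number from compound 3 to compound 4 (0.88 log units; beyond the scatter) in this assay for this single change. The earlier compounds shown here could not show this, since compound 1 and compound 2 also differ in where the chloromethyl arm sits, whereas this pair shows that, with the arm placed as in compound 3, this position of the core strongly affects growth inhibition. No data at hand explain the size of this step.

Going by these compounds, whether the gain belongs to chloro itself or would also come with another group at this position stays open, and an amine, a methoxy group or a fluoro there would help to decide. On these data alone, it is also open whether chloro at this position would give a similar step with the chloromethyl arm placed as in compound 1.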